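The source may hold more compounds than are shown below. What is called first, only, known or untested is meant among the compounds shown, and "the series" means these compounds.

The shared core appears first in compound 1 `COc1ccc(S(=O)(=O)Oc2ccccc2NC(=O)c2ccccc2)cc1`. In a functional assay on NCI-H460 cells (Homo sapiens) for antiproliferative activity (on this read-out higher numbers stand for weaker inhibition and lower numbers for stronger inhibition), compound 1 gives 410 nM. Compound 2 `COc1ccc(S(=O)(=O)Oc2ccccc2NC(=O)c2ccc3ncccc3c2)cc1` carries quinolin-6-yl in place of phenyl on the carbonyl carbon. In this assay compound 2 reaches only > 10000 nM, which is a limit of the assay and not a number. That change gave an at least 24-fold higher number from compound 1 to compound 2 (1.38 log units; beyond the scatter), and because the limit of > 10000 nM in this assay, at which 1 of the 2 values shown sits, applies to compound 2, the true size of that step may be larger still. Compound 3 `COc1ccc(S(=O)(=O)Oc2ccccc2NC(=O)Nc2ccccc2)cc1` has not yet been measured. Its difference from compound 2 is anilino in place of quinolin-6-yl on a carbonyl carbon. Among the compounds with values here, the only measured step that bears on this is the one from compound 1 to compound 2, which was large and went toward weaker inhibition; compound 3 undoes the quinolin-6-yl and returns to a single six-membered carbon ring, now joined through an anilino. A step of an at least 8.3-fold lower number from compound 2 to compound 3 (0.92 log units; beyond the scatter) is therefore expected, toward stronger inhibition, though its exact size cannot be fixed while compound 2 stands at a limit. Compound 3 is estimated at 1200 nM in this assay, with a range from 250 nM to 8000 nM.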

Compound 3, half-maximal inhibitory concentration: > 10000 nM
Compound 3: only a limit was reported; the forecaster's own chance of this, stated with the estimate: 20%; at least 8.3-fold (0.92 log units) between middle value and limit.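

Anilino in place of phenyl on the carbonyl carbon gave an at least 24-fold higher number from compound 1 to compound 3 (1.38 log units; beyond the scatter) in this assay, so the loss is not confined to quinolin-6-yl: a single six-membered carbon ring joined through anilino also ends at the limit. Of the three compounds, only compound 1 has a readable value, 410 nM, and at this position the directly attached phenyl is the only group shown that gives one. Compound 2 and compound 3 both stand at a limit of the assay, not at a number, and the step between them cannot be read: the limit of > 10000 nM in this assay, at which 2 of the 3 values shown sit.

From the compounds shown here alone, how far quinolin-6-yl and anilino each lie beyond that limit stays open, and so does any order between them. Also open, going by these compounds, is whether a methyl, a cyclohexyl or a benzyl on the carbonyl carbon would give a readable value in this assay, and how such a value would compare with that of compound 1.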